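Benzylcarbamoyl in Place of Butylsulfonyl on the Shared Core

This account rests on a few compounds, and the source may have more. Where it says the series, first, only, none or still open, it means among the compounds named here.

Within the data shown here, in a functional assay for binding affinity, with Homo sapiens as the target, read by fluorescence and flow cytometry (a higher number here means weaker binding, a lower number tighter binding), compound 1 `O=C(NC[C@H](NS(=O)(=O)c1cccs1)C(=O)O)c1cc2cc(CCC3CCNCC3)sc2s1` gives 0.15 nM, while compound 2 `CCCCS(=O)(=O)N[C@@H](CNC(=O)c1cc2cc(CCC3CCNCC3)sc2s1)C(=O)O` gives 5.6 nM, the higher of the two numbers measured so far. Compound 3 `O=C(NCc1ccccc1)N[C@@H](CNC(=O)c1cc2cc(CCC3CCNCC3)sc2s1)C(=O)O` keeps the core of compound 2 but carries benzylcarbamoyl in place of butylsulfonyl on an amine nitrogen. Among the measured compounds shown here, only one measured step bears on this change. With butyl in place of thiophen-2-yl on a sulfonyl sulfur, it is a 37-fold higher number from compound 1 to compound 2 (1.57 log units; beyond the scatter), so losing a ring there went with a large rise in the number. Compound 3 brings a ring back, a six-membered aromatic ring of carbon only, which suggests a move towards a lower number. For the measured compounds named here, the evidence is indirect, however, since no measured compound lacks the sulfonyl, and only part of that earlier size is expected. The expected change is a 2.8-fold lower number from compound 2 to compound 3 (0.45 log units; beyond the scatter). For compound 3 the estimated value in this assay is 2 nM, with an expected range from 0.4 nM to 10 nM.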

Compound 3, dissociation constant: 94 nM
For compound 3 the middle estimate is 47-fold (1.67 log units) below the measured one; measured number outside the range, above it.
By their numbers in this assay, from the lowest: compound 1; then compound 2; then compound 3.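

In this assay, a ring on this amine nitrogen proves no guide to the number by itself: compound 1 and compound 3 both carry one, yet benzylcarbamoyl in place of (thiophen-2-yl)sulfonyl gives a 630-fold higher number from compound 1 to compound 3 (2.80 log units; beyond the scatter), while benzylcarbamoyl in place of butylsulfonyl, despite adding a ring, gives a 17-fold higher number from compound 2 to compound 3 (1.22 log units; beyond the scatter). Among these three compounds, both that keep a sulfonyl on the nitrogen stand lower than the one with benzylcarbamoyl, and none goes against that order, so the position responds strongly to what is attached there, and the ring-free butyl group of compound 2 ranks ahead of the benzylcarbamoyl group. No measurement available here accounts for this order.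

The change swaps the link to the nitrogen and the group beyond it together, so the compounds shown leave open how much of the rise belongs to the carbamoyl and how much to the benzyl. A benzylsulfonyl or a butylcarbamoyl group on the same amine nitrogen of the shared core would separate the two.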